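The source may report more compounds than this note shows. Statements on the series, on what has been measured and on what is new or still open speak of the compounds shown alone.

Of the compounds shown here, three have been measured in a functional assay on HepG2 cells (Homo sapiens) for cytotoxicity, read by MTT assay, with a stated time of 72 h; on this read-out higher numbers stand for weaker inhibition and lower numbers for stronger inhibition. Compound 1, `O=C(Nc1ccc(Oc2ccnc3[nH]ccc23)cc1)c1nn(-c2ccc(Cl)c(F)c2)ccc1=O`, gives 5240 nM. Compound 2, `Cn1ccc2c(Oc3ccc(NC(=O)c4nn(-c5ccc(Br)cc5)ccc4=O)cc3F)ccnc21`, is reported only as a limit of the assay, > 60000 nM. Compound 3, `Cc1cc(=O)n(-c2ccc(F)cc2)nc1C(=O)Nc1ccc(Oc2ncnc3[nH]ccc23)cc1`, likewise reaches only a limit of the assay, > 60000 nM. Compound 3 therefore stands among the weaker members of the set: its result is not a number but the boundary of what this assay can resolve, and two of the three results rest at that boundary (the limit of > 60000 nM in this assay, at which 2 of the 3 values shown sit).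

Compound 4, `Cc1ccc(-n2nc(C(=O)Nc3ccc(Oc4ncnc5[nH]ccc45)cc3)c(C)cc2=O)cc1`, is the next candidate. It differs from compound 3 in one place: methyl in place of fluoro on an aromatic carbon. Among the compounds with values here, no pair of measured compounds differs by a single change, so the size of this kind of step has not been observed here, and nothing measured so far ties a change at this position to a shift in cytotoxicity. The step from compound 3 to compound 4 in this assay is expected to be a step that the limit leaves unreadable from compound 3 to compound 4, that is, no movement beyond the usual scatter. Compound 4 is accordingly expected to give about 70000 nM, within a range from 30000 nM to 200000 nM, and most likely the assay will again report only a limit.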

Compound 4, half-maximal inhibitory concentration: 7460 nM
Beside the measured number, compound 4's estimate is 9.4-fold (0.97 log units) above it; measured number outside the range, below it.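

In this assay, within the data shown here, exchanging 4-fluorophenyl for 4-methylphenyl gives the first single change that can be read in this set: an at least 8.0-fold lower number from compound 3 to compound 4 (0.90 log units; beyond the scatter). The position, on an aromatic carbon para to a large group, is therefore not a silent one, since replacing one heavy atom there, with no hydrogen-bond donor or acceptor gained or lost, is enough to give a clear change in the read-out. The full size of the step stays unknown because compound 3, with > 60000 nM, gives a limit of the assay and not a number: the limit of > 60000 nM in this assay, at which 2 of the 4 values shown sit.

The compounds shown leave open whether this gain belongs to the methyl group in particular or would also appear with other groups at the same place, such as an ethyl group, a methoxy group or an amine. They also leave open why the number falls, and whether the same exchange would act in the same way on a different core, such as that of compound 1.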